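Swapping methyl for bromo on a shared tricyclic scaffold

The source may report more compounds than this note shows. Statements on the series, on what has been measured and on what is new or still open speak of the compounds shown alone.

Measured compounds:
compound 1, `COC(=O)[C@@]1(C)CCC=C2[C@@H]1CC[C@@H](C)[C@]2(C)Cc1c[nH]c2ccc(Br)cc12`, 16000 nM
compound 2, `COC(=O)[C@@]1(C)CCC=C2[C@@H]1CC[C@@H](C)[C@]2(C)Cc1c(C)[nH]c2ccccc12`, 14000 nM
compound 3, `COC(=O)[C@@]1(C)CCC=C2[C@@H]1CC[C@@H](C)[C@]2(C)Cc1c(C)[nH]c2ccc(C)cc12`, 25000 nM

Of the compounds shown here, three built on the same core have been tested in a functional assay on HBL-100 cells (Homo sapiens) for inhibition, read by sulforhodamine B assay, with a stated time of 48 h; on this read-out higher numbers stand for weaker inhibition of growth and lower numbers for stronger inhibition of growth. Compound 1 gives 16000 nM, compound 2 gives 14000 nM, and compound 3 gives 25000 nM. Compound 3 has the highest number of the three, yet all three lie within the usual scatter of one another, so no order among them can be claimed.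

Compound 4, `COC(=O)[C@@]1(C)CCC=C2[C@@H]1CC[C@@H](C)[C@]2(C)Cc1c(C)[nH]c2ccc(Br)cc12`, has not yet been measured. It differs from compound 3 in one place: bromo in place of methyl on an aromatic carbon. Going by the values given here, only one step among the measured compounds is known, a 1.8-fold higher number from compound 2 to compound 3 (0.25 log units; within the scatter), and it concerns adding a methyl rather than exchanging it for bromo, so it bears only loosely on this change. Compound 1 carries a bromo at that position and sits close to the others. No step beyond the scatter is therefore expected in this assay. The estimate for compound 4 is 18000 nM, ranging from 8000 nM to 40000 nM, meaning an expected step of a 1.4-fold lower number from compound 3 to compound 4 (0.14 log units; within the scatter).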

Compound 4, concentration for 50% growth inhibition: 15000 nM
Beside the measured number, compound 4's estimate is 1.2-fold (0.08 log units) above it; the measured number falls inside the stated range.
By their numbers in this assay, from the lowest: compounds 2, 4, 1 and 3 (each within the scatter of the next).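

At this position on the six-membered aromatic ring, bromo, methyl and hydrogen can now be compared directly in this assay, and neither exchange moves the number beyond the scatter, with a 1.7-fold lower number from compound 3 to compound 4 (0.22 log units; within the scatter) and a 1.1-fold higher number from compound 2 to compound 4 (0.03 log units; within the scatter). Methyl in place of hydrogen on an aromatic carbon also stays within the scatter, with a 1.1-fold lower number from compound 1 to compound 4 (0.03 log units; within the scatter). Read on two cores, that same change gives steps that agree within the scatter: the same change on two cores in this assay, a 1.8-fold higher number (0.25 log units; within the scatter) from compound 2 to compound 3 and a 1.1-fold lower number (0.03 log units; within the scatter) from compound 1 to compound 4, 1.9-fold (0.28 log units) apart, within the scatter of two such steps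

Going by these compounds alone, every step so far lies within the scatter, so it remains open whether this position can influence the number at all. An amine or a carboxylic acid on this aromatic carbon would test that, as both differ more from methyl and bromo than those two differ from each other.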